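The source may report more compounds than this note shows. Statements on the series, on what has been measured and on what is new or still open speak of the compounds shown alone.

Values in an ADME assay on PBMC cells (Homo sapiens) for cytotoxicity, read by resazurin assay, with a stated time of 72 h; a higher number here means a weaker inhibitor, a lower number a stronger inhibitor:
- compound 1 `CCCCCCCCCCCCCC(=O)C1OC(=O)c2c(OC)cccc21`: 14.5 ug/mL
- compound 2 `CCCCCCCCCCCCCCCc1cccc(OC)c1C(=O)OC`: > 25 ug/mL

Compound 2 gives no number, only a limit, > 25 ug/mL. Going by the values given here, the sole number belongs to compound 1, at 14.5 ug/mL. Compound 3 `CCCCCCCCCCCCCCC(Br)c1cccc(OC)c1C(=O)OC` differs from compound 2 by one change: bromo in place of hydrogen on a saturated chain carbon bound to an aromatic carbon and a saturated chain carbon. Among the compounds with values here, no measured step covers this change, so the expectation is loose. A small move toward a lower number is expected, an at least 1.2-fold lower number from compound 2 to compound 3 (0.09 log units; that floor lies within the scatter), and another report at the limit remains possible. For compound 3 the estimate is 20 ug/mL, with an expected range of 8 ug/mL to 45 ug/mL.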

Compound 3, half-maximal inhibitory concentration: > 25 ug/mL
Compound 3: no number, only a limit; the forecaster's own chance of this, stated with the estimate: 45%; middle value at least 1.2-fold (0.09 log units) from the limit.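

Compound 2 and compound 3 both report only a limit in this assay, so no step can be read between them: the limit of > 25 ug/mL in this assay, at which 2 of the 3 values shown sit. From the compounds shown here alone, whether bromo in place of hydrogen changes the value at all stays open.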